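Cyano in Place of Trifluoromethyl: An Expected Limit

The source may hold more compounds than are shown below. What is called first, only, known or untested is meant among the compounds shown, and "the series" means these compounds.

Compound 1 `COc1cccc2sc(NC(=O)c3ccc(C(F)(F)F)cc3)nc12` was tested in a functional assay on SK-HEP1 cells (Homo sapiens) for antiproliferative activity, read by sulforhodamine B assay; a higher number here means a weaker inhibitor of growth, a lower number a stronger inhibitor of growth. There compound 1 reaches only the limit of > 10 ug/mL, not a number. Compound 2 `COc1ccc(C(=O)Nc2nc3cc(OC)ccc3s2)cc1` also stops at the limit of > 10 ug/mL in this assay. Both results sit at the limit of > 10 ug/mL in this assay, at which 2 of the 2 values shown sit. Compound 3 `COc1cccc2sc(NC(=O)c3ccc(C#N)cc3)nc12` differs from compound 1 by cyano in place of trifluoromethyl on an aromatic carbon. For the measured compounds named here, no measured step between compounds is available, so no change beyond the scatter is expected, as the estimated step that the limit leaves unreadable from compound 1 to compound 3 shows. Compound 3 is therefore expected to give about 15 ug/mL, between 5 ug/mL and 50 ug/mL.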

Compound 3, concentration for 50% growth inhibition: > 10 ug/mL
Compound 3: a limit, no number; the forecaster's own chance of this, stated with the estimate: 80%; the middle value does not contradict the limit.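

For the compounds shown here, compound 1 and compound 3 each give only a limit, not a number, in this assay, so no step between them can be read: the limit of > 10 ug/mL in this assay, at which 3 of the 3 values shown sit. The compounds shown leave open whether cyano and trifluoromethyl differ in growth inhibition at all.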